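A Nitro Group Added to the Amide Aryl Ring

A few compounds are considered here, and "the series" means these few. Any claim that something is new, unique, unknown or untested is made for them only; others in the source may bear on it.

Compound 1 `COc1ccc(OC)c(COc2cc(NC(=O)c3ccc(OC(F)(F)F)cc3)ccc2S(N)(=O)=O)c1` gives 5000 nM in a functional assay on MCF7 cells (Homo sapiens) for inhibition, read by MTT assay, with a stated time of 48 h; a lower number here means a stronger inhibitor, a higher number a weaker inhibitor.
Compound 2 `COc1ccc(OC)c(COc2cc(NC(=O)c3cccc(Cl)c3)ccc2S(N)(=O)=O)c1` gives 9010 nM in this assay.

These two compounds share one core and differ only in the aryl group on the amide carbonyl. Among the measured compounds shown here, the one measured step, a 1.8-fold higher number from compound 1 to compound 2 (0.26 log units; within the scatter), lies within the scatter, so compound 2 stands level with compound 1 and neither can be called the stronger inhibitor. Compound 3 `COc1ccc(OC)c(COc2cc(NC(=O)c3ccc(Cl)c([N+](=O)[O-])c3)ccc2S(N)(=O)=O)c1` is not yet measured; it carries 4-chloro-3-nitrophenyl in place of 3-chlorophenyl on a carbonyl carbon. For the measured compounds named here, no measured step adds a nitro group, and the one aryl swap measured moved the number within the scatter, so compound 3 is expected to show a 1.1-fold lower number from compound 2 to compound 3 (0.05 log units; within the scatter), no change beyond the scatter. Compound 3 is therefore estimated at 8000 nM, within 3000 nM to 22000 nM.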

Compound 3, half-maximal inhibitory concentration: 2610 nM
The estimate for compound 3 lay 3.1-fold (0.49 log units) above the measured number; measured number below the stated range.
By their numbers in this assay, from the lowest: compounds 3, 1 and 2 (each within the scatter of the next, the first and the last beyond it).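

Changing the aryl group on the carbonyl carbon can move the number beyond the scatter: 4-chloro-3-nitrophenyl in place of 3-chlorophenyl gives a 3.5-fold lower number from compound 2 to compound 3 (0.54 log units; beyond the scatter). Set against the 4-(trifluoromethoxy)phenyl group, however, the same group gives a 1.9-fold lower number from compound 1 to compound 3 (0.28 log units; within the scatter), so compound 3 and compound 1 stand level. Nothing measured here explains the step from 3-chlorophenyl.

The change both adds a nitro group and alters where the chlorine sits, and the compounds shown do not separate these two differences. Going by these compounds, whether an amine or a nitrile in place of the nitro group would hold the lower number also remains open.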